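Methyl to methoxymethyl: compound 2 to compound 3

The source may hold more compounds than are shown below. What is called first, only, known or untested is meant among the compounds shown, and "the series" means these compounds.

Measured so far in a functional assay on cells (Endothelial cell, Homo sapiens) for inhibition, read by radioligand binding; on this read-out higher numbers stand for weaker inhibition and lower numbers for stronger inhibition:
- compound 1 (`COc1ccc2[nH]c(C(N)=O)c(OC(C)C)c2c1`) gives 8000 nM
- compound 2 (`COc1ccc2c(c1)c(OC(C)C)c(C(N)=O)n2C`) gives 10000 nM

For the measured compounds named here, compound 2 at 10000 nM sits within the scatter of compound 1, its only neighbour on these numbers. The change to compound 3 (`COCn1c(C(N)=O)c(OC(C)C)c2cc(OC)ccc21`) is methoxy in place of hydrogen on a saturated chain carbon bound to an aromatic nitrogen and reads methoxy in place of hydrogen on a saturated chain carbon bound to an aromatic nitrogen, or methyl to methoxymethyl. Going by the values given here, the one measured step bearing on this change is a 1.3-fold higher number from compound 1 to compound 2 (0.10 log units; within the scatter) for methyl in place of hydrogen on an aromatic nitrogen. Among the compounds with values here, that single step stays within the scatter, and no measured compound carries methoxymethyl. In this assay the expected outcome is a 1.1-fold lower number from compound 2 to compound 3 (0.05 log units; within the scatter) and thus no shift beyond the scatter. Compound 3 is estimated at 9000 nM with a range from 4000 nM to 20000 nM in this read-out.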

Compound 3, half-maximal inhibitory concentration: 34000 nM
Compound 3: the middle estimate sits 3.8-fold (0.58 log units) below what was measured; the whole stated range lies below it.
By their numbers in this assay, from the lowest: compounds 1 and 2 (each within the scatter of the next); then compound 3.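

In this assay the substituent on the aromatic nitrogen now registers: methoxymethyl in place of hydrogen gives a 4.3-fold higher number from compound 1 to compound 3 (0.63 log units; beyond the scatter) and moves the number beyond the scatter, whereas methyl in place of hydrogen gave a 1.3-fold higher number from compound 1 to compound 2 (0.10 log units; within the scatter) and stayed within it. Extending methyl to methoxymethyl gives a 3.4-fold higher number from compound 2 to compound 3 (0.53 log units; beyond the scatter) as a modest loss of inhibition, so this position accepts methyl without a measurable change but not methoxy on the saturated chain carbon. Nothing available explains why this added methoxy weakens inhibition.

Still open, from the compounds shown here alone, is whether the higher number follows the oxygen of the methoxy or the chain length alone; an ethyl group on the aromatic nitrogen would separate the two. Also open, going by these compounds, is whether an amine or a carboxylic acid at the end of such a chain would move the number in the same direction.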